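Methoxy for vinyl on the fused five-membered aromatic ring

The source may report more compounds than this note shows. Statements on the series, on what has been measured and on what is new or still open speak of the compounds shown alone.

The series shares one core that carries a phenyl methylamide and a chain ending in a trifluoromethyl-substituted benzene. In a functional assay on CHO cells for antagonist activity at Orexin receptor type 2 (Homo sapiens), read by FLIPR and calcium flux (on this read-out lower numbers stand for stronger inhibition and higher numbers for weaker inhibition), compound 1 `CNC(=O)[C@@H](c1ccccc1)N1CCn2c(CC3CC3)nc(Cl)c2[C@@H]1CCc1ccc(C(F)(F)F)cc1` gives 35 nM. For the measured compounds named here, compound 2 `CNC(=O)[C@@H](c1ccccc1)N1CCn2c(COC)nc(Cl)c2[C@@H]1CCc1ccc(C(F)(F)F)cc1` gives 25 nM in this assay; the step of a 1.4-fold lower number from compound 1 to compound 2 (0.15 log units; within the scatter) is the only single-point change measured so far. Compound 3 `C=Cc1nc(CC)n2c1C(CCc1ccc(C(F)(F)F)cc1)N([C@@H](C(=O)NC)c1ccccc1)CC2` gives 23 nM in this assay and so stands within the scatter of both compound 1 and compound 2.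

Compound 4 `CCc1nc(OC)c2n1CCN([C@@H](C(=O)NC)c1ccccc1)C2CCc1ccc(C(F)(F)F)cc1` differs from compound 3 in one place: methoxy in place of vinyl on an aromatic carbon. Going by the values given here, no measured step exchanges a substituent on this aromatic carbon. Among the compounds with values here, the one measured step, a 1.4-fold lower number from compound 1 to compound 2 (0.15 log units; within the scatter), also brings in a methoxy, but at another place, on a saturated chain carbon, and it stayed within the scatter; it bears on the present change only loosely. Nothing in the measured set points to a step beyond the scatter in either direction in this assay. The expectation for compound 4 is therefore a step of a 1.1-fold higher number from compound 3 to compound 4 (0.04 log units; within the scatter), which is no real change. Compound 4 is estimated at 25 nM in this assay, with a range from 8 nM to 80 nM that allows for an untested position.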

Compound 4, half-maximal inhibitory concentration: 73 nM
Estimate against measurement, compound 4: 2.9-fold (0.47 log units) below; the range from low to high includes it.
By their numbers in this assay, from the lowest: compounds 3, 2 and 1 (each within the scatter of the next); then compound 4.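

In this assay, methoxy in place of vinyl on this aromatic carbon gives a 3.2-fold higher number from compound 3 to compound 4 (0.50 log units; beyond the scatter), a modest change and the only step shown in the series that lies beyond the scatter. The position therefore responds to an exchange between two groups of 2 heavy atoms each, so the heavy-atom count alone does not settle the value here, and methoxy does not read the same at every place: on a saturated chain carbon it gave a 1.4-fold lower number from compound 1 to compound 2 (0.15 log units; within the scatter), which stayed within the scatter. No measurement at hand accounts for the step at the aromatic carbon.

This position rests on a single pair, and that pair changes several counted features at once: methoxy brings an oxygen and a hydrogen-bond acceptor, while vinyl takes away a double bond, and the step cannot be assigned to any one of these. On these data alone, it remains open whether an ethoxy group, a nitrile or an amine on this aromatic carbon would stay with vinyl in this assay or move with methoxy, and whether the same exchange would give a similar step with the other substituents of the shared core changed.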